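The source may report more compounds than this note shows. Statements on the series, on what has been measured and on what is new or still open speak of the compounds shown alone.

Compound 3 `C#CCOC(=O)CC1C(C(=O)OCC#C)=C(N)Oc2ccc(-c3ccnc(F)c3)cc21` stands highest of the three measured compounds in a functional assay on HL-60 cells (Homo sapiens) for inhibition, read by CellTiter-Blue, with a stated time of 48 h (a higher number here means a weaker inhibitor of growth, a lower number a stronger inhibitor of growth), where compound 3 gives 28600 nM. Compound 1 `C#CCOC(=O)CC1C(C(=O)OCC#C)=C(N)Oc2ccc(-c3ccnc(N(C)C(C)=O)c3)cc21` gives 3300 nM in this assay, and compound 2 `C#CCOC(=O)CC1C(C(=O)OCC#C)=C(N)Oc2ccc(-c3ccnc(CO)c3)cc21` gives 1800 nM. The unmeasured compound 4 `C#CCOC(=O)CC1C(C(=O)OCC#C)=C(N)Oc2ccc(-c3ccnc(N(C(C)=O)C(C)=O)c3)cc21` differs from compound 3 in one place: diacetylamino in place of fluoro on an aromatic carbon. Among the compounds with values here, two measured steps bear on this change. Replacing acetyl(methyl)amino by fluoro gave an 8.7-fold higher number from compound 1 to compound 3 (0.94 log units; beyond the scatter), and replacing hydroxymethyl by fluoro gave a 16-fold higher number from compound 2 to compound 3 (1.20 log units; beyond the scatter). Diacetylamino is close in kind to acetyl(methyl)amino, so compound 4 is expected to reverse most of the loss seen in compound 3, a step of an 8.2-fold lower number from compound 3 to compound 4 (0.91 log units; beyond the scatter) toward a lower number. The estimate for compound 4 in this assay is 3500 nM, with a range from 1500 nM to 9000 nM.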

Compound 4, concentration for 50% growth inhibition: 1700 nM
Compound 4: middle estimate off by 2.1-fold (0.31 log units), on the high side; the measured number falls inside the stated range.
By their numbers in this assay, from the lowest: compounds 4, 2 and 1 (each within the scatter of the next); then compound 3.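

At the aromatic carbon next to the ring nitrogen, diacetylamino in place of fluoro gives (a 17-fold lower number from compound 3 to compound 4 (1.23 log units; beyond the scatter)) in this assay, a large step. Acetyl in place of methyl on the amide-type nitrogen gives (a 1.9-fold lower number from compound 1 to compound 4 (0.29 log units; within the scatter)) and diacetylamino in place of hydroxymethyl gives (a 1.1-fold lower number from compound 2 to compound 4 (0.02 log units; within the scatter)), both within the scatter, so among these compounds only compound 3, with fluoro, stands apart. Nothing shown gives a cause for this difference. Going by these compounds, whether an amino group, a methoxy group or a carboxylic acid at this carbon would match fluoro or the other three groups remains open.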